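The compounds below may be only part of what the source reports. "The series", "measured", "known", "first", "only" and "open" are said of these compounds alone.

Three compounds have been measured in an assay on isolated protein for inhibition of histone deacetylase 4 (Homo sapiens), read by chemiluminescence, with a stated time of 3 h; on this read-out lower numbers stand for stronger inhibition and higher numbers for weaker inhibition:

compound 1 `COc1ccc(-c2cnc(NC(=O)CCCCCCNC(=O)C(O)(O)C(F)(F)F)s2)cc1`, 2500000 nM
compound 2 `O=C(CCCCCCNC(=O)C(O)(O)C(F)(F)F)Nc1ncc(-c2ccc(Br)cc2)s1`, 1700000 nM
compound 3 `COc1ccc2sc(NC(=O)CCCCCCNC(=O)C(O)(O)C(F)(F)F)nc2c1`, 1900000 nM

All three carry the same chain and amide linkage and differ only in the aromatic part. Compound 3 stands with its value within the scatter of both compound 1 and compound 2, so no order among the three can be claimed. Compound 4 `O=C(CCCCCCNC(=O)C(O)(O)C(F)(F)F)Nc1nc2ccccc2s1` differs from compound 3 by hydrogen in place of methoxy on an aromatic carbon. Among the measured compounds shown here, the one measured step that bears on a change of a substituent on an aromatic carbon is a 1.5-fold lower number from compound 1 to compound 2 (0.17 log units; within the scatter), and it lay within the scatter. Compound 4 is therefore expected to show no step beyond the scatter in this assay, the expected change being a 1.1-fold higher number from compound 3 to compound 4 (0.02 log units; within the scatter). For compound 4 the estimate is 2000000 nM, with a range from 900000 nM to 4500000 nM.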

Compound 4, half-maximal inhibitory concentration: 430000 nM
Beside the measured number, compound 4's estimate is 4.7-fold (0.67 log units) above it; measured number outside the range, below it.
By their numbers in this assay, from the lowest: compound 4; then compounds 2, 3 and 1 (each within the scatter of the next).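

In this assay, among the compounds shown here, hydrogen in place of methoxy on this aromatic carbon gives a 4.4-fold lower number from compound 3 to compound 4 (0.65 log units; beyond the scatter) and so is the only step here beyond the scatter. For the compounds shown here, the earlier change on an aromatic carbon, a 1.5-fold lower number from compound 1 to compound 2 (0.17 log units; within the scatter), stayed within the scatter, so this position on the fused system is the first seen to respond to a change of substituent. Nothing available accounts for the step.

From the compounds shown here alone, it remains open whether fluoro, methyl or an amine at this carbon would stay near compound 4 or return towards compound 3. Going by these compounds, whether the other carbons of this ring respond alike also remains open.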